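Amide substituent change and microsomal half-life

This account rests on a few compounds, and the source may have more. Where it says the series, first, only, none or still open, it means among the compounds named here.

Compound 1: `Cn1cc(NC(=O)c2ccncc2Nc2cc(-c3ccc4ccn(C)c4c3)c3nccnc3c2)cn1`, 0.2 h
Compound 2: `CC(=O)N1CCC(NC(=O)c2ccncc2Nc2cc(-c3ccc4ccn(C)c4c3)c3nccnc3c2)CC1`, 0.117 h

In an ADME assay on microsomes from liver (Mus musculus, strain CD-1) for metabolic stability, read by LC-MS, tested at 2 uM (on this read-out lower numbers stand for a shorter-lived compound and higher numbers for a longer-lived compound), compound 1 gives 0.2 h, the higher of the two numbers; its nearest neighbour is compound 2, with a 1.7-fold lower number from compound 1 to compound 2 (0.23 log units; within the scatter). Compound 3, `CN1CCC(N(C)C(=O)c2ccncc2Nc2cc(-c3ccc4ccn(C)c4c3)c3nccnc3c2)C1`, differs from compound 1 by methyl(1-methylpyrrolidin-3-yl)amino in place of (1-methyl-1H-pyrazol-4-yl)amino on a carbonyl carbon. Within the data shown here, the only measured step that bears on this change is the one from compound 1 to compound 2, where the group on the carbonyl carbon was likewise exchanged and the result was a 1.7-fold lower number from compound 1 to compound 2 (0.23 log units; within the scatter). Since that exchange stayed within the scatter, no step beyond the scatter is expected for compound 3 either, and the estimated step is a 1.3-fold lower number from compound 1 to compound 3 (0.12 log units; within the scatter). Compound 3 is therefore expected to give about 0.15 h in this assay, within a range from 0.05 h to 0.45 h.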

Compound 3, half-life: > 1 h
Compound 3: a limit, no number; the forecaster's own chance of this, stated with the estimate: 5%; at least 6.6-fold (0.82 log units) between middle value and limit.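

At the group on the carbonyl carbon, the earlier exchange stayed within the scatter, but methyl(1-methylpyrrolidin-3-yl)amino now gives an at least 5.0-fold higher number from compound 1 to compound 3 (0.69 log units; beyond the scatter) and, against the acetylated partner, an at least 8.5-fold higher number from compound 2 to compound 3 (0.93 log units; beyond the scatter). This shows that a change at this place can shift the half-life in this assay beyond the scatter, and that the direction here is towards a longer-lived compound. Compound 3 gives a limit of the assay and not a number, so both steps have only a lower bound: the limit of > 1 h in this assay, at which 1 of the 3 values shown sits.

The compounds shown leave open whether the step follows the pyrrolidine ring or the methyl group that replaces the amide hydrogen, since the two enter together. A plain (1-methylpyrrolidin-3-yl)amino group or a dimethylamino group on the same carbonyl carbon would bear on that question.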